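Clearance after leaving the oxetan-3-yl group behind

A few compounds are considered here, and "the series" means these few. Any claim that something is new, unique, unknown or untested is made for them only; others in the source may bear on it.

Going by the values given here, in an ADME assay on microsomes from liver (Homo sapiens) for pharmacokinetics (on this read-out higher numbers stand for fast clearance and lower numbers for slow clearance), compound 2 `Cc1c(Nc2nc(N)c3c(C#N)c(N4CCC[C@H]4C)n(C)c3n2)cnn1C1COC1` gives 14.3 mL/min/kg as its only number, and one further entry offers no single number. Compound 1 `Cc1nn(C2CCOC2)cc1Nc1nc(N)c2c(C#N)c(N3CCC[C@H]3C)n(C)c2n1` gives 76.7 mL/min/kg; 200 mL/min/kg (2 entries) in this assay and so shows a wide spread of its own (the several entries of compound 1 in this assay, 76.7 mL/min/kg; 200 mL/min/kg (2 entries)). Both of its entries stand higher than the number for compound 2.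

Compound 3 `Cc1nn(C)cc1Nc1nc(N)c2c(C#N)c(N3CCC[C@H]3C)n(C)c2n1` differs from compound 2 in one place 1,3-dimethyl-1H-pyrazol-4-yl in place of 5-methyl-1-(oxetan-3-yl)-1H-pyrazol-4-yl on a nitrogen on an aromatic ring with 1,3-dimethyl-1H-pyrazol-4-yl in place of 5-methyl-1-(oxetan-3-yl)-1H-pyrazol-4-yl on a nitrogen on an aromatic ring. Among the compounds with values here, no measured pair shows this change alone. A modest rise is expected, and the estimated size is a 1.7-fold higher number from compound 2 to compound 3 (0.24 log units; within the scatter) within the usual scatter. This expectation rests on compound 2 at 14.3 mL/min/kg lying under every number for compound 1, which leaves more room upward than downward. For compound 3 the estimated clearance is 25 mL/min/kg with an expected range from 10 mL/min/kg to 60 mL/min/kg for a repeat measurement.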

Compound 3, clearance: 70 mL/min/kg
Estimate against measurement, compound 3: 2.8-fold (0.45 log units) below; measured number outside the range, above it.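

In this assay, replacing 5-methyl-1-(oxetan-3-yl)-1H-pyrazol-4-yl with 1,3-dimethyl-1H-pyrazol-4-yl gives a 4.9-fold higher number from compound 2 to compound 3 (0.69 log units; beyond the scatter), the first step read directly at this place on a nitrogen on an aromatic ring. The low number of compound 2 therefore does not carry over to compound 3, and clearance in this series responds to this group. The step rests on single numbers, and a related compound shows how far repeated entries can spread: the several entries of compound 1 in this assay, 76.7 mL/min/kg; 200 mL/min/kg (2 entries).

The change alters both the oxetan-3-yl group and the place of the ring methyl, and the compounds shown cannot separate the two. They also leave open how a 2-methoxyethyl chain or an azetidin-3-yl group in this place would compare with oxetan-3-yl.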